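This account rests on a few compounds, and the source may have more. Where it says the series, first, only, none or still open, it means among the compounds named here.

The measured compounds, each in an assay on isolated protein for displacement of a labelled ligand from metabotropic glutamate receptor 5 (Homo sapiens), with a stated time of 60 min, tested at 1 uM; a higher number here means more inhibition at the concentration tested (going by the name of the read-out), a lower number less inhibition:

Compound 1, `COc1ccc2ncc(S(=O)(=O)c3ccc(C)c(Cl)c3)c(N3CCC(C)CC3)c2c1`, gives 85%.
Compound 2, `COc1ccc(S(=O)(=O)c2cnc3ccc(OC)cc3c2N2CCC(C)CC2)cc1`, gives 41%.
Compound 3, `COc1ccc(S(=O)(=O)c2cnc3cc(F)ccc3c2N2CCC(C)CC2)cc1`, gives 90%.

Compound 2 and compound 1 share a core and differ in one place: 3-chloro-4-methylphenyl in place of 4-methoxyphenyl on a sulfonyl sulfur. That single change makes a large step in this assay, a number 44 percentage points higher from compound 2 to compound 1 (beyond the scatter). Compound 3 carries a different core, and the difference between the two cores is not broken down here; its read-out lies within the scatter of compound 1, while compound 2 lies beyond the scatter below both of them.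

Compound 4, `Cc1ccc(S(=O)(=O)c2cnc3cc(F)ccc3c2N2CCC(C)CC2)cc1Cl`, has not yet been measured in this assay. It stands to compound 3 exactly as compound 1 stands to compound 2: 3-chloro-4-methylphenyl in place of 4-methoxyphenyl on a sulfonyl sulfur. The place of the change is the same in both pairs, so this is the same change made a second time, on the other core.

The earlier step was large and upward, and the same direction is expected here. Yet the size is expected to be much smaller because compound 3 already gives 90%, leaving little room in a read-out of this kind; the step from compound 3 to compound 4 is therefore estimated at a number 3 percentage points higher from compound 3 to compound 4 (within the scatter). For compound 4 the value in this assay is estimated at 93%, expected to fall between 82% and 99%.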

Compound 4, a percentage reported as inhibition, at one concentration (the size of the read-out at that concentration, not a potency): 93%
The estimate for compound 4 equals the measured number at the digits printed, and the stated range covers the measured number.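

In this assay, among these compounds, 3-chloro-4-methylphenyl in place of 4-methoxyphenyl on a sulfonyl sulfur gives a number 3 percentage points higher from compound 3 to compound 4 (within the scatter), so on the core of compound 3 the change produces no step that can be told from the scatter. The size of the step therefore does not carry over from one core to the other: the same change on two cores in this assay, a number 44 percentage points higher (beyond the scatter) from compound 2 to compound 1 and a number 3 percentage points higher (within the scatter) from compound 3 to compound 4, 41 percentage points apart, beyond the scatter of two such steps

Among the compounds shown here, this does not show that the change matters less on the second core at every concentration, since compound 3 at 90% and compound 4 at 93% are read-outs at a single concentration, and two compounds that read alike here could still show a stronger or weaker effect at another concentration; with only one pair on each core, it also shows nothing general about how this change behaves across the series.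

The compounds shown leave open how the same change would run on a third core whose 4-methoxyphenyl compound reads low, as compound 2 does. They also leave open what a plain phenyl, or a phenyl carrying a carboxylic acid or an amine, would give on the sulfonyl sulfur in place of either group.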